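The source may report more compounds than this note shows. Statements on the series, on what has been measured and on what is new or still open speak of the compounds shown alone.

Measured in a functional assay on Jurkat cells (Homo sapiens); a higher number here means a weaker inhibitor, a lower number a stronger inhibitor:
- Compound 1 `C[C@H](NC(=O)C(=O)NCc1ccc(Cl)cc1)C(=O)N[C@@H](CC(=O)O)C(=O)COc1c(F)c(F)cc(F)c1F`: 8.4 nM
- Compound 2 `Cc1cccc(CNC(=O)C(=O)N[C@@H](C)C(=O)N[C@@H](CC(=O)O)C(=O)COc2c(F)c(F)cc(F)c2F)c1`: 127 nM
- Compound 3 `Cc1ccc(CNC(=O)C(=O)N[C@@H](C)C(=O)N[C@@H](CC(=O)O)C(=O)COc2c(F)c(F)cc(F)c2F)cc1`: 50 nM

Compound 3, at 50 nM, holds the middle of the three values in this assay. Next is compound 4 `Cc1ccc(CNC(=O)C(=O)N[C@@H](C)C(=O)N[C@@H](CC(=O)O)C(=O)COc2c(F)c(F)cc(F)c2F)c(C)c1`, with methyl in place of hydrogen on an aromatic carbon, ortho to a large group and meta to a methyl group, which turns 4-methylbenzyl into 2,4-dimethylbenzyl (methyl in place of hydrogen on an aromatic carbon).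

For the measured compounds named here, no measured compound carries a group at this place, so the evidence is indirect. The closest guides are the shift of the methyl, a 2.5-fold lower number from compound 2 to compound 3 (0.40 log units; beyond the scatter), and the exchange of chloro for methyl, a 6.0-fold higher number from compound 1 to compound 3 (0.77 log units; beyond the scatter). Both are modest, and they show that this aromatic ring responds to small changes. Compound 2, whose methyl lies elsewhere on the ring, gives the highest number at 127 nM, so a modest rise is expected rather than a gain.

The expected step is a 1.5-fold higher number from compound 3 to compound 4 (0.18 log units; within the scatter). Compound 4 is estimated at 75 nM, with an expected range of 22 nM to 250 nM.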

Compound 4, half-maximal inhibitory concentration: > 10000 nM
Compound 4: a limit, no number; the forecaster's own chance of this, stated with the estimate: 2%; middle value at least 130-fold (2.12 log units) from the limit.
By their numbers in this assay, from the lowest: compound 1; then compound 3; then compound 2. At a limit, above all of these: compound 4.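

Adding one methyl on an aromatic carbon, ortho to a large group and meta to a methyl group, gives an at least 200-fold higher number from compound 3 to compound 4 (2.30 log units; beyond the scatter), so this place on the ring is far less forgiving than the earlier changes of ring substituent suggested. The 2,4-dimethylbenzyl group also separates sharply from the other two benzyl groups: an at least 78-fold higher number from compound 2 to compound 4 (1.89 log units; beyond the scatter), and an at least 1100-fold higher number from compound 1 to compound 4 (3.07 log units; beyond the scatter). In this assay compound 4 stands as a limit and not a number, so these steps give only the smallest size the data allow: the limit of > 10000 nM in this assay, at which 1 of the 4 values shown sits.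

Still open, from the compounds shown here alone, is whether a fluoro, chloro or methoxy group at this place would behave as methyl does. Also open, going by these compounds, is whether a methyl here would have the same outcome on a ring without the second methyl group.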